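Series notes: hydroxy for chloro, step to compound 4

This account rests on a few compounds, and the source may have more. Where it says the series, first, only, none or still open, it means among the compounds named here.

Measured so far:
compound 1 `Fc1ccc(/C=N/c2sc3c(c2-c2nc4ccccc4s2)CCC3)cc1` — an ADME assay on cells (Rhabdomyosarcoma cell, Homo sapiens) for cytotoxicity, read by MTT assay, with a stated time of 72 h; a higher number here means that more compound is tolerated, a lower number that less compound is tolerated: 290 ug/mL
compound 2 `Clc1ccc(/C=N/c2sc3c(c2-c2nc4ccccc4s2)CCC3)cc1` — this assay: 342 ug/mL
compound 3 `Clc1ccccc1/C=N/c1sc2c(c1-c1nc3ccccc3s1)CCC2` — this assay: 123 ug/mL

Compound 3 gives the lowest number of the three: a 2.4-fold lower number from compound 1 to compound 3 (0.37 log units; beyond the scatter) and a 2.8-fold lower number from compound 2 to compound 3 (0.44 log units; beyond the scatter), both modest and beyond the scatter. Compound 4 `Oc1ccccc1/C=N/c1sc2c(c1-c1nc3ccccc3s1)CCC2` differs from compound 3 by hydroxy in place of chloro on an aromatic carbon. Among the compounds with values here, no measured step exchanges a halogen for hydroxy. Within the data shown here, the one step that swaps a group on the same carbon, a 1.2-fold higher number from compound 1 to compound 2 (0.07 log units; within the scatter), stayed within the scatter; the two larger steps concern a change of position, not of group, and bear only loosely here. Compound 4 is therefore expected to stay near compound 3, with no step beyond the scatter expected: a 1.2-fold higher number from compound 3 to compound 4 (0.09 log units; within the scatter). For compound 4 the estimate in this assay is 150 ug/mL, range 70 ug/mL to 350 ug/mL.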

Compound 4, half-maximal cytotoxic concentration: 100 ug/mL
Compound 4: middle estimate off by 1.5-fold (0.18 log units), on the high side; the range from low to high includes it.
By their numbers in this assay, from the lowest: compounds 4 and 3 (each within the scatter of the next); then compounds 1 and 2 (each within the scatter of the next).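

In this assay, hydroxy in place of chloro at this position makes no change that can be told from the scatter: a 1.2-fold lower number from compound 3 to compound 4 (0.09 log units; within the scatter). The gap to the 4-chlorophenyl and 4-fluorophenyl compounds, seen first with 2-chlorophenyl, also holds with 2-hydroxyphenyl: a 3.4-fold lower number from compound 2 to compound 4 (0.53 log units; beyond the scatter) and a 2.9-fold lower number from compound 1 to compound 4 (0.46 log units; beyond the scatter). No measured evidence bears on this result.

Going by these compounds, whether an amine or a carboxylic acid on this same aromatic carbon would also stay within the scatter of compound 3 remains open.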